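The compounds below may be only part of what the source reports. "The series", "measured", "known", "first", "only" and "open" are said of these compounds alone.

Of the compounds shown here, three sharing one core have been tested in an ADME assay on HL-60 cells (Homo sapiens) for cytotoxicity, read by resazurin assay, with a stated time of 72 h; on this read-out lower numbers stand for an effect already at smaller amounts and higher numbers for an effect only at larger amounts of compound. Compound 1 `CN1CCC(CCn2c(N)nc3ccc(C(=O)c4ccccc4)cc32)CC1` gives a value that is a limit of this assay and not a number, reported as > 30000 nM. Compound 2 `Nc1nc2ccc(C(=O)c3ccccc3)cc2n1C[C@H]1CCCN1` likewise returns only a limit, > 30000 nM. Compound 3 `CN1CCC[C@@H]1Cn1c(N)nc2ccc(C(=O)c3ccccc3)cc21` also gives a limit in this assay, > 30000 nM. Because every value shown sits at the limit of > 30000 nM in this assay, at which 3 of the 3 values shown sit, the steps a step that the two limits leave unreadable from compound 1 to compound 2, a step that the two limits leave unreadable from compound 1 to compound 3 and a step that the two limits leave unreadable from compound 2 to compound 3 cannot be read for size or direction. Compound 3 thus stands where all three measured compounds stand, at the limit, with no ordering among them.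

The unmeasured compound 4 `CC(C)Cn1c(N)nc2ccc(C(=O)c3ccccc3)cc21` differs from compound 3 by isopropyl in place of 1-methylpyrrolidin-2-yl on a saturated chain carbon bound to an aromatic nitrogen. Among the compounds with values here, none of the three measured steps gives a readable size, so no step of a known size bears on this change; what the measured compounds do show is that swaps among the groups on the saturated chain carbon bound to the aromatic nitrogen have left every value at the limit. Compound 4 is therefore expected to give about 30000 nM in this assay, with a range from 10000 nM to 100000 nM, most likely again as a limit. The expected step of a number no higher from compound 3 to compound 4 (the limit leaves the size open) is estimated to be none beyond the scatter.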

Compound 4, half-maximal effective concentration: > 30000 nM
Compound 4: no number, only a limit; the forecaster's own chance of this, stated with the estimate: 80%; the middle value lies on the limit itself.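

In this assay compound 4 gives > 30000 nM as a limit and not a number. The steps to compound 4 from compound 1, compound 2 and compound 3 therefore cannot be read, because all the values sit at one limit: the limit of > 30000 nM in this assay, at which 4 of the 4 values shown sit. The compounds shown leave open at what concentration, if any, each would reach the half-maximal effect.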